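One group exchanged on compound 2

A few compounds are considered here, and "the series" means these few. Any claim that something is new, unique, unknown or untested is made for them only; others in the source may bear on it.

- compound 1 `O=S(=O)(NCCNC(=S)Nc1cccc(Cl)c1)c1ccc(-c2ccccc2OCc2cccc(O)c2)s1` gives 1800 nM (a number)
- compound 2 `COc1ccc(NC(=O)NCCNS(=O)(=O)c2ccc(-c3ccccc3OCc3ccccc3)s2)cc1` gives > 50000 nM (a limit)

Both results come from a functional assay on HL-60 cells (Homo sapiens) for inhibition, read by CCK-8 assay, with a stated time of 48 h (a higher number here means a weaker inhibitor, a lower number a stronger inhibitor), and only compound 1 has a true number. Compound 2 stands at > 50000 nM in this assay, which is a limit of the assay and not a number. Compound 3 `O=S(=O)(NCCNC(=S)Nc1cccc(Cl)c1)c1ccc(-c2ccccc2OCc2ccccc2)s1` differs from compound 2 in one place: a group of 10 heavy atoms (7 carbon, 1 nitrogen, 1 sulfur, 1 chlorine; one six-membered aromatic ring of carbon only) in place of a group of 11 heavy atoms (8 carbon, 1 nitrogen, 2 oxygen; one six-membered aromatic ring of carbon only), on an amine nitrogen. The entering group is also found in compound 1 at 1800 nM in this assay, so a large move towards a stronger inhibitor is expected. The expected change is an at least 20-fold lower number from compound 2 to compound 3 (1.30 log units; beyond the scatter) in this assay. For compound 3 the estimate is 2500 nM, with an expected range of 800 nM to 9000 nM in this assay.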

Compound 3, half-maximal inhibitory concentration: > 50000 nM
Compound 3: a limit, no number; the forecaster's own chance of this, stated with the estimate: 7%; middle value at least 20-fold (1.30 log units) from the limit.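

In this assay, the group entering on the amine nitrogen does not on its own bring a readable number: compound 3 gives > 50000 nM, a limit of the assay and not a number. Hydrogen in place of hydroxy on an aromatic carbon gives an at least 27-fold higher number from compound 1 to compound 3 (1.44 log units; beyond the scatter), so with this entering group the hydroxy of compound 1 matters. The step between compound 2 and compound 3 cannot be read, because both values are limits: the limit of > 50000 nM in this assay, at which 2 of the 3 values shown sit.

As far as these compounds go, whether an amine or a carboxylic acid on that aromatic carbon would keep a readable number remains open. So does whether the hydroxy would also give a number alongside the (4-methoxyphenyl)carbamoyl group of compound 2.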